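The source may hold more compounds than are shown below. What is called first, only, known or untested is meant among the compounds shown, and "the series" means these compounds.

Compound 3 `NS(=O)(=O)Oc1ccc2c(c1)CN(C(=O)c1ccc(N3CCCCC3)cc1)CC2` is the starting point. Among the compounds with values here, in an assay on HEK293 cells for inhibition of Steryl-sulfatase (Homo sapiens), tested at 0.1 uM (on this read-out lower numbers stand for a weaker effect and higher numbers for a stronger effect at the one concentration tested), compound 3 gives 11.5%, the second highest of the three numbers so far. Its nearest neighbour is compound 1 `NS(=O)(=O)Oc1ccc2c(c1)CN(C(=O)c1ccc(N3CCC(N4CCCCC4)CC3)cc1)CC2`, which in this assay gives 8.5%; the step of a number 3 percentage points higher from compound 1 to compound 3 (within the scatter) is within the scatter, so these two are not told apart. Within the data shown here, the furthest is compound 2 `CC(C)CCN(CCC(C)C)c1ccc(C(=O)N2CCc3ccc(OS(N)(=O)=O)cc3C2)cc1`, which in this assay gives 47%; the step of a number 35.5 percentage points lower from compound 2 to compound 3 (beyond the scatter) is the only large step seen.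

Compound 4 `CN(CCN1CCCCC1)c1ccc(C(=O)N2CCc3ccc(OS(N)(=O)=O)cc3C2)cc1` is not yet measured. It differs from compound 3 in one place: methyl(2-(piperidin-1-yl)ethyl)amino in place of piperidin-1-yl on an aromatic carbon

Among the measured compounds shown here, two steps bear on this. Opening the ring on the aromatic carbon into a diisopentylamino group, as in compound 2, brought a large rise; adding a second piperidin-1-yl elsewhere, as in compound 1, changed nothing beyond the scatter. Compound 4 carries an open-chain amino group with a second ring nitrogen, so a modest rise is expected, and the step of a number 10.5 percentage points higher from compound 3 to compound 4 (beyond the scatter) is the estimate. For compound 4 the expected value is 22%, within 6% to 45%.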

Compound 4, a percentage reported as inhibition, at one concentration (the size of the read-out at that concentration, not a potency): 0.3%
The estimate for compound 4 lay 21.7 percentage points above the measured number, and the stated range ends above it.
By their numbers in this assay, from the lowest: compounds 4, 1 and 3 (each within the scatter of the next, the first and the last beyond it); then compound 2.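

At this aromatic carbon, an open-chain amino group does not by itself raise the number in this assay: methyl(2-(piperidin-1-yl)ethyl)amino gives the step of a number 46.7 percentage points lower from compound 2 to compound 4 (beyond the scatter), and even against the simple piperidin-1-yl ring it gives the step of a number 11.2 percentage points lower from compound 3 to compound 4 (beyond the scatter). The contrast between a ring and an open chain therefore does not account for the high number of compound 2, since of the two open-chain groups only diisopentylamino goes with a large number. No measurement here explains the fall.

The compounds shown do not separate the effect of the second nitrogen from that of the rest of the group. An open chain ending in a cyclohexyl ring, which keeps the ring but has carbon in place of that nitrogen, would address this question at the same position.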